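The source may report more compounds than this note shows. Statements on the series, on what has been measured and on what is new or still open speak of the compounds shown alone.

Of the compounds shown here, three sharing one core have been measured in an assay on cells for inhibition of Protein-serine O-palmitoleoyltransferase porcupine (Homo sapiens), read by reporter gene assay; on this read-out lower numbers stand for stronger inhibition and higher numbers for weaker inhibition. Compound 1 `CN1C(=O)C2=C(C1=O)N(CC(=O)Nc1ccc(-c3ccccc3)cc1)CCC2` gives 12 nM in this assay. Compound 2 `CN1C(=O)C2=C(C1=O)N(CC(=O)Nc1ccc(-c3cccnc3)nn1)CCC2` gives 29 nM, a higher number than compound 1 and a gap that lies beyond the usual scatter. Compound 3 `CN1C(=O)C2=C(C1=O)N(CC(=O)Nc1ccc(-c3ccccc3)nc1)CCC2` gives 6 nM; its gap to compound 1 stays within the scatter, so the two cannot be told apart. Compound 1 thus stands second highest among the three numbers, closest to compound 3 and furthest from compound 2.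

The next compound, compound 4 `CN1C(=O)C2=C(C1=O)N(CC(=O)Nc1ccc(-c3ccncc3)cc1)CCC2`, is built from compound 1 by a single change: pyridin-4-yl in place of phenyl on an aromatic carbon. Among the compounds with values here, no pair of measured compounds differs only in this way, so no directly comparable step exists; compound 2 and compound 3 each combine this kind of nitrogen placement with other changes. For that reason only a modest step is expected, with no clear direction beyond the scatter, and the estimated step of a 1.3-fold higher number from compound 1 to compound 4 (0.10 log units; within the scatter) reflects this. Compound 4 is therefore expected to give about 15 nM in this assay, within a range from 5 nM to 45 nM.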

Compound 4, half-maximal inhibitory concentration: 72 nM
Estimate against measurement, compound 4: 4.8-fold (0.68 log units) below; the measured number lies above the stated range.
By their numbers in this assay, from the lowest: compounds 3 and 1 (each within the scatter of the next); then compound 2; then compound 4.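

In this assay the swap of phenyl for pyridin-4-yl on this aromatic carbon, para to a large group, clearly weakens inhibition (a 6.0-fold higher number from compound 1 to compound 4 (0.78 log units; beyond the scatter)). Within the data shown here, this is the first change here that can be read on its own, and it shows that one ring nitrogen in place of a ring carbon, with the count of heavy atoms unchanged, is enough to move the number beyond the scatter. Nothing measured here explains this step.

On these data alone, it remains open whether pyridin-3-yl or pyridin-2-yl in the same place would cost as much, since compound 2 carries pyridin-3-yl but also differs from compound 1 in a second place. As far as these compounds go, it is equally open how a methoxy group or an amine on the phenyl ring of compound 1 would read.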